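A Fluoro Substituent on an Unresponsive Benzoyl Series

The compounds below may be only part of what the source reports. "The series", "measured", "known", "first", "only" and "open" are said of these compounds alone.

Compound 1 `COc1cc(-c2nnc(SCC(=O)c3ccccc3)n2N)cc(OC)c1OC` is tested in a functional assay on PC-3 cells (Homo sapiens) for antiproliferative activity, read by MTT assay, with a stated time of 48 h; on this read-out lower numbers stand for stronger inhibition and higher numbers for weaker inhibition. In this assay compound 1 gives > 100000 nM, which is a limit of the assay rather than a number. Compound 2 `COc1cc(-c2nnc(SCC(=O)c3ccc(Br)cc3)n2N)cc(OC)c1OC` gives > 100000 nM, again a limit. Compound 3 `COc1cc(-c2nnc(SCC(=O)c3ccc(F)c(F)c3)n2N)cc(OC)c1OC` gives > 100000 nM, also a limit. The steps between these compounds are accordingly unreadable: a step that the two limits leave unreadable from compound 1 to compound 2, a step that the two limits leave unreadable from compound 1 to compound 3 and a step that the two limits leave unreadable from compound 2 to compound 3. Among the measured compounds shown here, the only evidence across the set is the limit of > 100000 nM in this assay, at which 3 of the 3 values shown sit.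

Compound 4 `COc1cc(-c2nnc(SCC(=O)c3ccccc3F)n2N)cc(OC)c1OC` differs from compound 1 by fluoro in place of hydrogen on an aromatic carbon. The measured steps that bear on this change, bromo in place of hydrogen and 3,4-difluorophenyl in place of phenyl, left no readable size, so no direction can be taken from them. Because the limit of > 100000 nM in this assay, at which 3 of the 3 values shown sit, holds for every measured compound, compound 4 is expected to sit at that limit as well, with the step that the limit leaves unreadable from compound 1 to compound 4 estimated to be small. The estimate for compound 4 is 150000 nM, within 50000 nM to 500000 nM.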

Compound 4, half-maximal inhibitory concentration: 43100 nM
Compound 4: middle estimate off by 3.5-fold (0.54 log units), on the high side, and the stated range ends above it.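

In this assay, among the compounds shown here, the 2-fluorophenyl group is the first at this benzoyl position to bring a value inside the measurable range, with an at least 2.3-fold lower number from compound 1 to compound 4 (0.36 log units; beyond the scatter) when fluoro replaces hydrogen ortho to a large group. Halogen on the ring does not by itself produce this: compound 4 also stands apart from the other halogenated compounds, with an at least 2.3-fold lower number from compound 3 to compound 4 (0.36 log units; beyond the scatter) and an at least 2.3-fold lower number from compound 2 to compound 4 (0.36 log units; beyond the scatter). The rest of the series still gives no readable size, and the steps among compounds 1, 2 and 3 remain unreadable: the limit of > 100000 nM in this assay, at which 3 of the 4 values shown sit.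

What the compounds shown leave open is whether the response belongs to fluoro itself or would also follow from another group at the same place, such as chloro, methoxy or an amine. They also leave open how a single fluoro on either of the other ring carbons named in these groups, as in 3-fluorophenyl or 4-fluorophenyl, would compare.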